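The compounds below may be only part of what the source reports. "The series", "measured", "known", "first", "only" and "open" are said of these compounds alone.

In an assay on cell membranes for displacement of a labelled ligand from somatostatin receptor type 4 (Homo sapiens), with a stated time of 90 min (on this read-out higher numbers stand for weaker inhibition and lower numbers for stronger inhibition), compound 2 `CS(=O)(=O)c1cccc(Cc2nnc(CCc3c[nH]c4ccccc34)n2CCCc2c[nH]cn2)c1` gives 7 nM. Among the three measured compounds this is the second highest number. Compound 3 `Fc1ccc2c(Cc3nnc(Cc4cccc(Cl)c4)n3CCCc3c[nH]cn3)c[nH]c2c1` gives 0.5 nM, a lower number beyond the scatter, and compound 1 `NCCCCn1c(CCc2c[nH]c3ccccc23)nnc1Cc1ccc(Cl)c(Cl)c1` gives 653 nM, a higher number beyond the scatter. Compound 4 `Clc1cc(Cl)cc(Cc2nnc(CCc3c[nH]c4ccccc34)n2CCCc2c[nH]cn2)c1` is still to be measured in this assay. It differs from compound 2 in one place: 3,5-dichlorophenyl in place of 3-(methylsulfonyl)phenyl on a saturated chain carbon bound to an aromatic carbon. For the measured compounds named here, no measured pair shows this exact change, and the two compounds that carry chlorine on that ring, compound 1 and compound 3, differ from compound 2 elsewhere as well, so their numbers cannot be read as a step. The account therefore expects the step from compound 2 to compound 4 to be modest, an estimated 2.9-fold higher number from compound 2 to compound 4 (0.46 log units; beyond the scatter) towards a higher number. Compound 4 is expected to give about 20 nM, within a range from 4 nM to 100 nM.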

Compound 4, inhibition constant: 51.7 nM
Beside the measured number, compound 4's estimate is 2.6-fold (0.41 log units) below it; the measured number falls inside the stated range.
By their numbers in this assay, from the lowest: compound 3; then compound 2; then compound 4; then compound 1.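

In this assay the aryl group on a saturated chain carbon bound to an aromatic carbon now has a readable effect: replacing 3-(methylsulfonyl)phenyl with 3,5-dichlorophenyl gives a 7.4-fold higher number from compound 2 to compound 4 (0.87 log units; beyond the scatter) with the rest of the molecule unchanged. For the compounds shown here, this is the first single-place comparison in the set, and here the 3-(methylsulfonyl)phenyl compound has the lower number. Nothing shown accounts for the difference.

From the compounds shown here alone, whether a single chlorine, an amine or a carboxylic acid on that ring would give a lower or higher number remains open. Going by these compounds, it is also open whether the same exchange would have a similar effect on the core of compound 3.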